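A few compounds are considered here, and "the series" means these few. Any claim that something is new, unique, unknown or untested is made for them only; others in the source may bear on it.

Compound 1 `C[C@@H](O)[C@H]1C(=O)N2C(C(=O)OCOC(=O)OC3Cc4ccccc4C3)=C(S[C@@H]3CN[C@H](C(=O)N(C)C)C3)[C@H](C)[C@H]12` carries its variable group on an oxygen next to a carbonyl group; in an ADME assay on a cell-free system (plasma, Cavia porcellus, strain Dunkin-Hartley) for metabolic stability, read by HPLC, tested at 5 mM (on this read-out lower numbers stand for a shorter-lived compound and higher numbers for a longer-lived compound), compound 1 gives 0.015 h. Compound 2 `C[C@@H](O)[C@H]1C(=O)N2C(C(=O)OCOC(=O)O[C@@H]3CCCCc4ccccc43)=C(S[C@@H]3CN[C@H](C(=O)N(C)C)C3)[C@H](C)[C@H]12` gives 0.015 h in this assay, and the step of no change at the digits printed from compound 1 to compound 2 (within the scatter) lies within the scatter, so compound 1 stands level with compound 2. Compound 3 `C[C@@H](O)[C@H]1C(=O)N2C(C(=O)OCOC(=O)OC3CCc4ccccc4C3)=C(S[C@@H]3CN[C@H](C(=O)N(C)C)C3)[C@H](C)[C@H]12` differs from compound 1 by 1,2,3,4-tetrahydronaphthalen-2-yl in place of 2,3-dihydro-1H-inden-2-yl on an oxygen next to a carbonyl group. Within the data shown here, only one measured step bears on this change, no change at the digits printed from compound 1 to compound 2 (within the scatter), at the same place, and it showed no change. For compound 3 the expected step is therefore no change at the digits printed from compound 1 to compound 3 (within the scatter), nothing beyond the scatter. Compound 3 is expected to give 0.015 h in this assay, within 0.0075 h to 0.03 h.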

Compound 3, half-life in the Cavia porcellus assay: 0.0283 h
The estimate for compound 3 lay 1.9-fold (0.28 log units) below the measured number; the measured number falls inside the stated range.
By their numbers in the Cavia porcellus assay, from the lowest: compounds 1, 2 and 3 (each within the scatter of the next).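

In the Cavia porcellus assay the step of a 1.9-fold higher number from compound 1 to compound 3 (0.28 log units; within the scatter) and the step of a 1.9-fold higher number from compound 2 to compound 3 (0.28 log units; within the scatter) show that a six-membered non-aromatic ring at this place, on an oxygen next to a carbonyl group, reads the same within the scatter as the five- and seven-membered rings. In a physicochemical assay for metabolic stability, read by HPLC, with a stated time of 120 min, at pH 7.4, tested at 100 uM (on this read-out higher numbers stand for a more stable compound and lower numbers for a less stable compound), compound 1 gives 70% and compound 3 gives 78% and these two values also lie within the scatter of each other. Nothing available here explains these results. The compounds shown leave open whether a group on this oxygen bearing an amine or a carboxylic acid would move the half-life beyond the scatter. They also leave open how an open alkyl chain would read there.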